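Extending a methyl to ethyl on compound 1

This account rests on a few compounds, and the source may have more. Where it says the series, first, only, none or still open, it means among the compounds named here.

Measured compounds:
compound 1 `Cc1ccc2[nH]c(-c3cccc(C)n3)nc2c1` 42%
compound 2 `Cc1cccc(-c2nc3cc(Cl)ccc3[nH]2)n1` 39%
compound 3 `Cc1cccc(-c2nc3cc(O)ccc3[nH]2)n1` 6%

In a functional assay on the whole organism with Rattus norvegicus as the target, read by paw edema, with a stated time of 3 h, at a dose of 100 mg/kg by the oral route (on this read-out lower numbers stand for less inhibition and higher numbers for more inhibition at the one dose given (going by the name of the read-out)), compound 1 gives 42% and stands highest of the three numbers, though compound 2 with 39% sits within the scatter of it, so no order between the two can be claimed. Compound 3 gives 6% and lies far below both. The two large moves are a number 36 percentage points lower from compound 1 to compound 3 (beyond the scatter) and a number 33 percentage points lower from compound 2 to compound 3 (beyond the scatter); the small one is a number 3 percentage points lower from compound 1 to compound 2 (within the scatter). All three measured steps change the group on an aromatic carbon of the shared core, not the chain.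

The unmeasured compound 4 `CCc1cccc(-c2nc3cc(C)ccc3[nH]2)n1` differs from compound 1 by methyl in place of hydrogen on a saturated chain carbon bound to an aromatic carbon. Going by the values given here, none of the measured steps bears on this change: each of them swaps a group on an aromatic carbon, whereas here a methyl is added to a saturated chain carbon bound to an aromatic carbon, turning methyl into ethyl. Among the compounds with values here, with no guiding step, the account expects no movement beyond the scatter, that is a number 2 percentage points lower from compound 1 to compound 4 (within the scatter) is expected to be small. Compound 4 is therefore estimated at 40%, within 20% to 58%.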

Compound 4, a percentage reported as inhibition, in the whole organism at one dose (the size of the read-out at that dose, not a potency): 10%
Estimate against measurement, compound 4: 30 percentage points above; measured number outside the range, below it.
By their numbers in this assay, from the lowest: compounds 3 and 4 (each within the scatter of the next); then compounds 2 and 1 (each within the scatter of the next).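

In this assay, turning methyl into ethyl, with methyl in place of hydrogen on a saturated chain carbon bound to an aromatic carbon, comes with a number 32 percentage points lower from compound 1 to compound 4 (beyond the scatter), so the read-out responds to a change at this place as well as to changes on an aromatic carbon. The entering group counts only 1 heavy atom, with no ring, no hydrogen-bond donors or acceptors and no net charge, so a large step here takes no more than this small addition, whereas the swap of methyl for chloro on an aromatic carbon gave only a number 3 percentage points lower from compound 1 to compound 2 (within the scatter). Nothing among the data shown accounts for the size of this step.

The compounds shown leave open whether a longer chain such as propyl, a branched isopropyl group or an amine at this place would keep the number as low, and whether bare hydrogen in place of the methyl of compound 1 would move it at all. They also leave open whether ethyl has the same effect when chloro replaces the other methyl, as in compound 2.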